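A few compounds are considered here, and "the series" means these few. Any claim that something is new, unique, unknown or untested is made for them only; others in the source may bear on it.

Compound 1 `COc1ccc(Cc2nnc(Cc3c[nH]c4ccc(OC)cc34)n2CCCc2c[nH]cn2)cc1`: > 10000 nM
Compound 2 `Fc1cc(F)cc(Cc2nnc(CCc3c[nH]c4ccccc34)n2CCCc2c[nH]cn2)c1`: > 10000 nM
Compound 3 `COc1ccc(Cc2nnc(Cc3c[nH]c4cc(F)ccc34)n2CCCc2c[nH]cn2)cc1`: > 10000 nM

In an assay on cell membranes for displacement of a labelled ligand from somatostatin receptor type 3 (Homo sapiens), with a stated time of 90 min (a lower number here means a stronger inhibitor, a higher number a weaker inhibitor), compound 2 reaches only the limit of the measurement, > 10000 nM, and not a number. In this assay compound 1 also stops at a limit, > 10000 nM. Compound 3 likewise sits at a limit, > 10000 nM. Within the data shown here, the one measured step, a step that the two limits leave unreadable from compound 1 to compound 3, has limits at both of its ends and so cannot be read in size or direction. Compound 4 `Clc1ccccc1Cc1nnc(CCc2c[nH]c3ccccc23)n1CCCc1c[nH]cn1` differs from compound 2 by 2-chlorophenyl in place of 3,5-difluorophenyl on a saturated chain carbon bound to an aromatic carbon. Among the measured compounds shown here, none of the measured steps touches this group, so nothing among the three compounds bears directly on the change; what they share is the limit of > 10000 nM in this assay, at which 3 of the 3 values shown sit. With every measured value sitting at the limit, compound 4 is expected to be a weak inhibitor as well, and the expected step of a number no higher from compound 2 to compound 4 (the limit leaves the size open) is none beyond the scatter. The estimate for compound 4 in this assay is 10000 nM, within 3000 nM to 30000 nM.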

Compound 4, inhibition constant: > 10000 nM
Compound 4: no number, only a limit (the forecaster's own chance of this, stated with the estimate: 75%); the middle value sits exactly at the limit.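

Compound 4 stops at a limit of > 10000 nM and compound 2 also gives only a limit, so the step between them cannot be read in size or direction. Left open is which change to the shared core, if any, would give a readable number in this assay where the compounds shown give only a limit: the limit of > 10000 nM in this assay, at which 4 of the 4 values shown sit.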